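The compounds below may be only part of what the source reports. "The series", "measured", "known", "first", "only" and "open" are said of these compounds alone.

In an ADME assay on HepG2 cells (Homo sapiens) for cytotoxicity (a higher number here means that more compound is tolerated, a lower number that less compound is tolerated), compound 3 (`CN(C)CC#Cc1cc2c(Nc3ccc(OCc4cccc(F)c4)c(Cl)c3)ncnc2s1`) gives > 32 uM, which is a limit and not a number. Compound 2 (`CC(C)(C)CC#Cc1cc2c(Nc3ccc(OCc4cccc(F)c4)c(Cl)c3)ncnc2s1`) gives > 32 uM, likewise a limit. Among the compounds with values here, compound 1 (`CN1CCN(CC#Cc2cc3c(Nc4ccc(OCc5cccc(F)c5)c(Cl)c4)ncnc3s2)CC1`) is the only one with a number, at 15 uM.

The next compound, compound 4 (`Fc1cccc(COc2ccc(Nc3ncnc4sc(C#CCN5CCNCC5)cc34)cc2Cl)c1`), differs from compound 3 as follows: piperazin-1-yl in place of dimethylamino on a saturated chain carbon bound to a triple-bonded carbon. So piperazin-1-yl takes the place of dimethylamino on a saturated chain carbon bound to a triple-bonded carbon.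

Compound 1 carries 4-methylpiperazin-1-yl at that place, the measured group nearest to piperazin-1-yl. The most relevant measured step is therefore an at least 2.1-fold higher number from compound 1 to compound 3 (0.32 log units; beyond the scatter). The change to compound 2 points the same way, with an at least 2.1-fold higher number from compound 1 to compound 2 (0.32 log units; beyond the scatter). The remaining step gives no size, as a step that the two limits leave unreadable from compound 2 to compound 3.

The change to compound 4 resembles the step to compound 3 run backwards, so a modest move to a lower number in this assay is expected. The expected step is an at least 2.0-fold lower number from compound 3 to compound 4 (0.30 log units; that floor lies within the scatter). For compound 4 the estimated value is 16 uM, with an expected range of 8 uM to 32 uM.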

Compound 4, half-maximal toxic concentration: 7.7 uM
For compound 4 the middle estimate is 2.1-fold (0.32 log units) above the measured one; the measured number lies below the stated range.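

In this assay, the piperazin-1-yl group on the saturated chain carbon bound to a triple-bonded carbon cannot be told apart from 4-methylpiperazin-1-yl, with a 1.9-fold lower number from compound 1 to compound 4 (0.29 log units; within the scatter), so hydrogen in place of methyl on the amine nitrogen in the ring makes no readable difference here. Against the two acyclic groups the separation is clear, with an at least 4.1-fold lower number from compound 3 to compound 4 (0.61 log units; beyond the scatter) and an at least 4.1-fold lower number from compound 2 to compound 4 (0.61 log units; beyond the scatter), and both sizes are floors only: the limit of > 32 uM in this assay, at which 2 of the 4 values shown sit.

Within these four compounds, the two with a piperazine ring give numbers, whatever sits on the ring amine nitrogen, whereas compound 2 and compound 3 give only limits.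

From the compounds shown here alone, whether the ring itself or its second nitrogen goes with the lower numbers stays open, and a morpholine or piperidine at this place would separate the two. Going by these compounds, the true sizes of the steps from compound 2 and compound 3 also remain unknown, and the step between those two cannot be read.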